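The compounds below may be only part of what the source reports. "The series", "measured", "known", "first", "only" and "open" are said of these compounds alone.

Measured in a functional assay on HepG2 cells (Homo sapiens) for cytotoxicity, read by WST assay, with a stated time of 24 h; on this read-out higher numbers stand for lower toxicity in this test and lower numbers for higher toxicity in this test:
- compound 1, `CCCC=Cc1cc(-c2ccc3cc(C(=O)O)ccc3c2)ccc1O`: 5.38 ug/mL
- compound 2, `CCCCCC=Cc1cc(-c2ccc3cc(C(=O)O)ccc3c2)ccc1O`: 2.44 ug/mL
- compound 3, `CCCC=Cc1cc(-c2ccc3cc(CO)ccc3c2)ccc1O`: 3.89 ug/mL

The numbers put compound 1 at the upper end of the three, with a 2.2-fold lower number from compound 1 to compound 2 (0.34 log units; beyond the scatter) and a 1.4-fold lower number from compound 1 to compound 3 (0.14 log units; within the scatter), so only the first of these steps separates it from a neighbour.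

Next is compound 4, `O=C(O)c1ccc2cc(-c3ccc(O)cc3)ccc2c1`. The change is hydrogen in place of pent-1-en-1-yl on an aromatic carbon, ortho to a hydroxy group. The carboxy group stays.

Only the chain step bears on this directly. Compound 2, with its ethyl extension, gave a 2.2-fold lower number from compound 1 to compound 2 (0.34 log units; beyond the scatter), so more chain went with a lower number, though this rests on a single pair. The hydroxymethyl exchange in compound 3 lies elsewhere on the core and says little here. Going by the values given here, no compound without the chain has been measured, so removing it entirely is an extrapolation well beyond that one step.

In this assay a move towards a higher number is therefore expected, larger than the chain step and beyond the scatter. The expected change is a 2.8-fold higher number from compound 1 to compound 4 (0.45 log units; beyond the scatter). For compound 4 the estimated value is 15 ug/mL, with an expected range of 6 ug/mL to 50 ug/mL.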

Compound 4, concentration lethal to 50% of the cells: > 32 ug/mL
Compound 4 gave a limit, no number; the forecaster's own chance of this, stated with the estimate: 20%; middle value at least 2.1-fold (0.32 log units) from the limit.
By their numbers in this assay, from the lowest: compounds 2, 3 and 1 (each within the scatter of the next, the first and the last beyond it). At a limit, above all of these: compound 4.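

In this assay compound 4 gives a limit of the assay and not a number: the limit of > 32 ug/mL in this assay, at which 1 of the 4 values shown sits.

Hydrogen in place of pent-1-en-1-yl, ortho to a hydroxy group, gives an at least 5.9-fold higher number from compound 1 to compound 4 (0.77 log units; beyond the scatter), and hydrogen in place of hept-1-en-1-yl at the same place gives an at least 13-fold higher number from compound 2 to compound 4 (1.11 log units; beyond the scatter). The earlier compounds shown here all carried a chain here and could only show a change with its length, whereas compound 4 shows that having an alkenyl chain at this position at all, with the carboxy group kept, goes with the lower numbers, and both of these steps are open-ended.

Still open, going by these compounds, is whether a short group such as methyl or ethyl, or a saturated pentyl chain, at this position would keep the lower numbers, so the point along the chain where the numbers start to fall is unsettled. Also open, on these data alone, is how hydroxymethyl in place of carboxy, as in compound 3, would read on a core without the chain.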